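The source may report more compounds than this note shows. Statements on the series, on what has been measured and on what is new or still open speak of the compounds shown alone.

Measured in a functional assay on RAW264.7 cells (Mus musculus) for inhibition, read by polymerase chain reaction, with stated times of 12 h and 6 h; on this read-out lower numbers stand for stronger inhibition and higher numbers for weaker inhibition:
- compound 1 `Cc1ccc(C)c(OCCCC(C)(C)C(=O)NC2CCN(Cc3ccc(Cl)cc3)CC2)c1`: 14800 nM
- compound 2 `Cc1ccc(CN2CCC(NC(=O)C(C)(C)CCCOc3cc(C)ccc3C)CC2)cc1`: 6540 nM
- compound 3 `COc1ccc(CN2CCC(NC(=O)C(C)(C)Oc3ccc(C(=O)c4ccc(Cl)cc4)cc3)CC2)cc1`: 4570 nM

Compound 3 gives the lowest number of the three, but it lies within the scatter of compound 2 and cannot be separated from it. Its number is clearly lower than that of compound 1.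

The next compound is compound 4 `CC(C)(Oc1ccc(C(=O)c2ccc(Cl)cc2)cc1)C(=O)NC1CCN(Cc2ccc(C(F)(F)F)cc2)CC1`, which has trifluoromethyl in place of methoxy on an aromatic carbon, taking 4-methoxybenzyl to 4-(trifluoromethyl)benzyl: trifluoromethyl in place of methoxy on an aromatic carbon. The change sits on an aromatic carbon of a six-membered aromatic ring of carbon only, para to a large group.

Among the measured compounds shown here, only one measured step offers guidance, a 2.3-fold lower number from compound 1 to compound 2 (0.35 log units; beyond the scatter), a modest change with methyl in place of chloro on an aromatic carbon. That step comes from a different core and involves neither methoxy nor trifluoromethyl, so it suggests only the likely size of a change and gives no firm direction. For the measured compounds named here, no measured pair tests this exchange directly.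

The expected change is small, a 1.2-fold higher number from compound 3 to compound 4 (0.08 log units; within the scatter), and no shift beyond the scatter is expected in this assay. Compound 4 is estimated at 5500 nM, with an expected range of 2000 nM to 15000 nM.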

Compound 4, half-maximal inhibitory concentration: 4400 nM
The estimate for compound 4 lay 1.3-fold (0.10 log units) above the measured number; the range from low to high includes it.
By their numbers in this assay, from the lowest: compounds 4, 3 and 2 (each within the scatter of the next); then compound 1.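

Among the compounds shown here, the step of a 1.0-fold lower number from compound 3 to compound 4 (0.02 log units; within the scatter) in this assay is the first direct reading of this exchange: replacing methoxy with trifluoromethyl, on an aromatic carbon para to a large group, gives no shift beyond the scatter. On this core, the position accepts the change from 4-methoxybenzyl to 4-(trifluoromethyl)benzyl even though methoxy counts a hydrogen-bond acceptor and trifluoromethyl none, so in this pair that acceptor is not required to hold the number at this level. No measured evidence bears on why the two groups read alike.

From the compounds shown here alone, whether an amine, a carboxylic acid or a longer chain on this same aromatic carbon would give a number beyond the scatter remains open, as the pair covers only methoxy and trifluoromethyl. Going by these compounds, the step of a 2.3-fold lower number from compound 1 to compound 2 (0.35 log units; beyond the scatter) belongs to the core of compound 1, so it also remains open whether methyl and chloro would separate in the same way on the core shared by compound 3 and compound 4.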